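This account rests on a few compounds, and the source may have more. Where it says the series, first, only, none or still open, it means among the compounds named here.

Compound 1, `O=C(NCCCCl)Nc1ccc(I)cc1`, in a functional assay on MCF7 cells (Homo sapiens) for antiproliferative activity, with a stated time of 48 h (on this read-out higher numbers stand for weaker inhibition and lower numbers for stronger inhibition), gives > 100000 nM, which is a limit of the assay and not a number.
Compound 2, `O=C(CCl)Nc1ccc(I)cc1`, in this assay gives 6200 nM.
Compound 3, `O=C(CCCCl)Nc1ccc(I)cc1`, in this assay gives > 100000 nM, again a limit and not a number.

Compound 3 therefore stands at the edge of what this assay can report, and it shares that place with compound 1, since (the limit of > 100000 nM in this assay, at which 2 of the 3 values shown sit). Only compound 2 gives a number. Among the measured steps, an at least 16-fold higher number from compound 2 to compound 3 (1.20 log units; beyond the scatter) is large, as is an at least 16-fold lower number from compound 1 to compound 2 (1.20 log units; beyond the scatter), while a step that the two limits leave unreadable from compound 1 to compound 3 cannot be read because both ends sit at a limit.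

Compound 4 is `C=CC(=O)Nc1ccc(I)cc1`. The change from compound 3 is vinyl in place of 3-chloropropyl on a carbonyl carbon. For the measured compounds named here, no measured compound carries a vinyl, so the nearest guide is the step of an at least 16-fold higher number from compound 2 to compound 3 (1.20 log units; beyond the scatter), where lengthening the chain on the carbonyl carbon sent the number up to the limit. Shortening that chain again in compound 4 is expected to reverse part of that, giving a lower number, though a vinyl is not a chloromethyl. The expected step is an at least 12-fold lower number from compound 3 to compound 4 (1.09 log units; beyond the scatter). Compound 4 is estimated at 8000 nM, with a range from 1500 nM to 60000 nM.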

Compound 4, half-maximal inhibitory concentration: 17000 nM
For compound 4 the middle estimate is 2.1-fold (0.33 log units) below the measured one; the range from low to high includes it.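

In this assay, the group on this carbonyl carbon does not need a chlorine to give a readable number: vinyl carries none and still gives an at least 5.8-fold lower number from compound 3 to compound 4 (0.76 log units; beyond the scatter), and against (3-chloropropyl)amino it gives an at least 5.8-fold lower number from compound 1 to compound 4 (0.76 log units; beyond the scatter). Vinyl does not fully match chloromethyl, with a 2.7-fold higher number from compound 2 to compound 4 (0.44 log units; beyond the scatter), yet among the compounds shown only these two short groups give numbers, while the two longer groups do not. The steps that start from compound 1 and compound 3 give only minimum sizes, because those two compounds sit at a limit and not at a number: the limit of > 100000 nM in this assay, at which 2 of the 4 values shown sit.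

The compounds shown do not separate the double bond of vinyl from its short length; an ethyl or a methyl on the same carbonyl carbon would address that, and a 2-chloroethyl would show how fast the number rises as the chlorine-bearing chain grows. As far as these compounds go, how any of these groups acts inside the cells also stays open, since a single cell read-out cannot tell one way of acting from another.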